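Swapping the cyclopropyl acyl group for a bromoallyl chain

The compounds below may be only part of what the source reports. "The series", "measured", "known", "first", "only" and "open" are said of these compounds alone.

Of the compounds shown here, three sharing one core have been tested in a functional assay on HCT-116 cells (Homo sapiens) for inhibition, read by MTT assay, with a stated time of 48 h; a lower number here means a stronger inhibitor, a higher number a weaker inhibitor. Compound 1, `COc1ccc(CN(C(=O)C2CC2)c2cc(OC)c(OC)c(OC)c2)cc1O`, gives 49 nM and stands lowest of the three numbers, meaning it is the strongest inhibitor among them. Compound 2, `COc1ccc(CNc2cc(OC)c(OC)c(OC)c2)cc1Br`, gives 48100 nM, and compound 3, `COc1cc(NCc2cccc(O)c2)cc(OC)c1OC`, gives 67700 nM; both gaps to compound 1 are far beyond the usual scatter. Compounds 2 and 3 each differ from compound 1 in more than one place, so no single change can be read from them, but together they show that the amide-bearing arrangement of compound 1 is where the strong inhibition sits.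

Compound 4, `COc1ccc(CN(C(=O)/C=C/CBr)c2cc(OC)c(OC)c(OC)c2)cc1O`, keeps that arrangement and changes only the acyl group: 3-bromoprop-1-en-1-yl in place of cyclopropyl on a carbonyl carbon. Among the compounds with values here, no measured pair isolates a change of this kind, so the size of the step is uncertain. The expectation is a modest move toward a higher number in this assay, possibly within the scatter, giving a step of a 1.6-fold higher number from compound 1 to compound 4 (0.21 log units; within the scatter) from compound 1 to compound 4. On that basis compound 4 is estimated at 80 nM, with a plausible range from 15 nM to 500 nM.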

Compound 4, half-maximal inhibitory concentration: 59 nM
Compound 4: middle estimate off by 1.4-fold (0.13 log units), on the high side; low and high end bracket the measured number.
By their numbers in this assay, from the lowest: compounds 1 and 4 (each within the scatter of the next); then compounds 2 and 3 (each within the scatter of the next).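

In this assay, within the data shown here, putting the 3-bromoprop-1-en-1-yl group in place of cyclopropyl on a carbonyl carbon gives a 1.2-fold higher number from compound 1 to compound 4 (0.08 log units; within the scatter), and this is the first comparison here that isolates a single change. At this place, whose other neighbour is the amide-type nitrogen, a three-membered carbon ring gives way to an open chain with a double bond and a bromine, yet the two numbers cannot be told apart, so strong inhibition in this assay does not depend on the cyclopropyl ring being present. Nothing measured here explains why these two different groups read alike.

A plain propenyl chain without the bromine, or a saturated 3-bromopropyl chain, would show whether the bromine or the double bond has any weight of its own at this carbonyl carbon. Going by these compounds, how far this tolerance reaches also stays open: a longer alkyl chain, a phenyl ring, an amine or a carboxylic acid on the same carbonyl carbon could give a very different number.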